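The source may report more compounds than this note shows. Statements on the series, on what has been measured and on what is new or still open speak of the compounds shown alone.

Measured so far:
Compound 1, `O=C(O)CCC/C=C\C[C@H]1[C@@H]2CCC(C2)[C@@H]1NS(=O)(=O)c1ccc([N+](=O)[O-])cc1`: 1400 nM in a functional assay (plasma) for inhibition, with Oryctolagus cuniculus as the target; a lower number here means a stronger inhibitor, a higher number a weaker inhibitor.
Compound 2, `COc1ccc(S(=O)(=O)N[C@H]2C3CC[C@H](C3)[C@@H]2C/C=C\CCCC(=O)O)cc1`: 1700 nM in this assay.

Compound 1 has the lower of the two numbers in this assay, but its nearest neighbour, compound 2, differs by only a 1.2-fold higher number from compound 1 to compound 2 (0.08 log units; within the scatter), a gap that is within the scatter, so the two stand level.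

Compound 3, `O=C(O)CCC/C=C\C[C@H]1[C@@H]2CCC(C2)[C@@H]1NS(=O)(=O)Cc1ccccc1`, has not been measured in this assay. It differs from compound 1 by benzyl in place of 4-nitrophenyl on a sulfonyl sulfur. Among the compounds with values here, the one measured step, from compound 1 to compound 2, swapped a group on the aromatic ring and gave a 1.2-fold higher number from compound 1 to compound 2 (0.08 log units; within the scatter), within the scatter; it says nothing direct about a benzyl in place of 4-nitrophenyl on the sulfonyl sulfur, for which no step has been measured. The expectation is therefore a step of about a 1.8-fold higher number from compound 1 to compound 3 (0.25 log units; within the scatter), with a wide range. Compound 3 is estimated at 2500 nM, between 700 nM and 9000 nM.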

Compound 3, half-maximal inhibitory concentration: 113000 nM
Estimate against measurement, compound 3: 45-fold (1.66 log units) below, outside the stated range (above it).
By their numbers in this assay, from the lowest: compounds 1 and 2 (each within the scatter of the next); then compound 3.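

At the sulfonyl sulfur, the group is not interchangeable in this assay: benzyl in place of 4-nitrophenyl gives an 81-fold higher number from compound 1 to compound 3 (1.91 log units; beyond the scatter), and benzyl in place of 4-methoxyphenyl gives a 66-fold higher number from compound 2 to compound 3 (1.82 log units; beyond the scatter). The swap of nitro for methoxy on the aromatic ring stayed within the scatter, whereas both steps to benzyl lie beyond it, so among these three compounds the large change comes with benzyl on the sulfonyl sulfur, from either aryl starting point. No available measurement bears on what lies behind this result.

As far as these compounds go, it remains open whether a plain phenyl on the sulfonyl sulfur would stand with compound 1 and compound 2 or with compound 3. From the compounds shown here alone, how a longer chain such as 2-phenylethyl, or an amine on the aromatic ring, would read is also open.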